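From 4-methoxyphenyl to 2,5-dihydroxyphenyl on a carbonyl carbon

This account rests on a few compounds, and the source may have more. Where it says the series, first, only, none or still open, it means among the compounds named here.

Compound 1 `COc1cc(OC)c(OC)cc1/C=C/C(=O)c1cc(OC(C)=O)ccc1OC(C)=O` gives 2.33 ug/mL
Compound 2 `COc1ccc(C(=O)/C=C/c2cc(OC)c(OC)cc2OC)cc1` gives 2.18 ug/mL
Compound 3 `COc1cc(OC)c(-c2cc(=O)c3ccc(O)cc3o2)cc1OC` gives 2.15 ug/mL

All three values come from a functional assay on cells (Erythrocyte, Rattus norvegicus) for inhibition, read by hemolysis, with a stated time of 1 h (on this read-out higher numbers stand for weaker inhibition and lower numbers for stronger inhibition), and lie within the usual scatter of one another. Compound 2 therefore stands in a tight group, and its number cannot be separated from those of compound 1 or compound 3 in this assay on these data. The next compound is compound 4 `COc1cc(OC)c(OC)cc1/C=C/C(=O)c1cc(O)ccc1O` and it has not yet been measured. It carries 2,5-dihydroxyphenyl in place of 4-methoxyphenyl on a carbonyl carbon and the rest of compound 2 is kept. Among the measured compounds shown here, no measured pair of compounds shows this change on its own, so its size cannot be read directly from the data. The three structures nevertheless all give closely similar numbers, so no step beyond the scatter is expected in either direction. The expected step of a 1.0-fold higher number from compound 2 to compound 4 (0.00 log units; within the scatter) is thus close to nil. For compound 4 the estimated value is 2.2 ug/mL with an expected range from 1.1 ug/mL to 4.5 ug/mL in this wide band.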

Compound 4, half-maximal inhibitory concentration: 2.1 ug/mL
Estimate against measurement, compound 4: 1.0-fold (0.02 log units) above; the measured number falls inside the stated range.
By their numbers in this assay, from the lowest: compounds 4, 3, 2 and 1 (each within the scatter of the next).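

In this assay, among the compounds shown here, 2,5-dihydroxyphenyl in place of 4-methoxyphenyl on a carbonyl carbon gives a 1.0-fold lower number from compound 2 to compound 4 (0.02 log units; within the scatter), and this is the first step that can be read as a change in one place. The position thus takes a group with 2 hydrogen-bond donors and 2 hydrogen-bond acceptors in place of one with 0 donors and 1 acceptor, with no step beyond the scatter on this read-out. No measurement offered here explains this result.

On these data alone, whether a different group on this carbonyl carbon, such as an amine-bearing ring or a carboxylic acid, would shift the number beyond the scatter remains open. Also open, as far as these compounds go, is what a phenyl with a single hydroxyl would give at this place.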